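Replacing 3-nitrophenyl with 3,4,5-trimethoxyphenyl on compound 3

The source may hold more compounds than are shown below. What is called first, only, known or untested is meant among the compounds shown, and "the series" means these compounds.

Measured so far in a functional assay on QGY-7703 cells (Homo sapiens) for cytotoxicity, read by MTT assay, with a stated time of 24 h; a lower number here means a stronger inhibitor, a higher number a weaker inhibitor:
Compound 1 `COc1cc(/C=C2\CN(S(=O)(=O)c3ccc(NC(C)=O)cc3)C/C(=C\c3cc(OC)c(OC)c(OC)c3)C2=O)cc(OC)c1OC` gives 1900 nM
Compound 2 `O=C1/C(=C/c2cccc([N+](=O)[O-])c2)CN(S(=O)(=O)c2ccc(F)cc2)C/C1=C\c1ccccc1F` gives 14900 nM
Compound 3 `CC(=O)Nc1ccc(S(=O)(=O)N2C/C(=C\c3cccc([N+](=O)[O-])c3)C(=O)/C(=C/c3ccccc3F)C2)cc1` gives 7850 nM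

Compound 3 (7850 nM) stands in the upper part of these numbers with compound 2 (14900 nM), while compound 1 (1900 nM) lies lower than both. Compound 4 `COc1cc(/C=C2\CN(S(=O)(=O)c3ccc(NC(C)=O)cc3)C/C(=C\c3ccccc3F)C2=O)cc(OC)c1OC` carries 3,4,5-trimethoxyphenyl in place of 3-nitrophenyl on a double-bonded chain carbon bound to a double-bonded ring carbon. Among the measured compounds shown here, the only measured step at a single place is a 1.9-fold lower number from compound 2 to compound 3 (0.28 log units; within the scatter) and it puts acetamido in place of fluoro on an aromatic carbon, so it does not test this change. The nearest evidence is compound 1 (1900 nM), which carries 3,4,5-trimethoxyphenyl twice and differs from compound 3 in more than this one place. Compound 4 shares one of those two changes, so it is expected to land part of the way from the value of compound 3 toward that of compound 1. The expected step is a 2.1-fold lower number from compound 3 to compound 4 (0.32 log units; beyond the scatter) and it points to a lower number. In this assay the estimate for compound 4 is 3800 nM with an expected range from 1500 nM as lower end to 9000 nM as upper end.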

Compound 4, half-maximal inhibitory concentration: 2680 nM
The estimate for compound 4 lay 1.4-fold (0.15 log units) above the measured number, and the stated range covers the measured number.
By their numbers in this assay, from the lowest: compounds 1 and 4 (each within the scatter of the next); then compounds 3 and 2 (each within the scatter of the next).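

In this assay, among the compounds shown here, this is the first comparison that isolates the group on a double-bonded chain carbon bound to a double-bonded ring carbon: 3,4,5-trimethoxyphenyl in place of 3-nitrophenyl gives a 2.9-fold lower number from compound 3 to compound 4 (0.47 log units; beyond the scatter), whereas the only earlier single-place step concerned acetamido and fluoro on an aromatic carbon and stayed within the scatter. The second exchange now available, 2-fluorophenyl in place of 3,4,5-trimethoxyphenyl, gives a 1.4-fold higher number from compound 1 to compound 4 (0.15 log units; within the scatter), so among these compounds only the step that removes 3-nitrophenyl lies beyond the scatter, and the gap between the numbers of compound 3 and compound 1 can now be traced to that single exchange. Nothing available here accounts for why the number moved at this position.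

The compounds shown leave open whether an aromatic ring bearing an amine or a carboxylic acid would give a number closer to that of compound 3 or of compound 4 at this place. They also leave open whether the step from 3-nitrophenyl to 3,4,5-trimethoxyphenyl would be of similar size with fluoro instead of acetamido on the aromatic carbon.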